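The source may report more compounds than this note shows. Statements on the series, on what has been measured and on what is new or still open speak of the compounds shown alone.

Compound 1 `O=C(CSc1nc2ccc(NC(=O)c3ccc([N+](=O)[O-])cc3)cc2s1)NCc1ccccc1` is set beside compound 4 `O=C(CSc1nc2ccc(NC(=O)c3ccccc3)cc2s1)NCc1ccccc1` in a functional assay on HepG2 cells (Homo sapiens) for cytotoxicity, read by MTT assay, with a stated time of 48 h; on this read-out lower numbers stand for stronger inhibition and higher numbers for weaker inhibition. In this assay compound 1 gives only a limit of the assay, > 100000 nM. Compound 2 `COc1ccc(CNC(=O)CSc2nc3ccc(NC(=O)c4ccc([N+](=O)[O-])cc4)cc3s2)cc1` likewise gives only a limit in this assay, > 100000 nM. Compound 3 `CNC(=O)CSc1nc2ccc(NC(=O)c3ccc(Cl)cc3)cc2s1` gives 15300 nM in this assay. For the measured compounds named here, the one measured step, a step that the two limits leave unreadable from compound 1 to compound 2, cannot be read because of the limit of > 100000 nM in this assay, at which 2 of the 3 values shown sit. Compound 4 differs from compound 1 by hydrogen in place of nitro on an aromatic carbon. Going by the values given here, no measured step covers this change, and the single step on record gives neither size nor direction, so in this assay no step beyond the usual scatter is expected in either direction. Compound 4 is therefore estimated at 80000 nM, between 20000 nM and 300000 nM. This estimate means an expected at least 1.2-fold lower number from compound 1 to compound 4 (0.09 log units; that floor lies within the scatter).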

Compound 4, half-maximal inhibitory concentration: 34200 nM
Compound 4: middle estimate off by 2.3-fold (0.37 log units), on the high side, and the stated range covers the measured number.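

Read in this assay, the change from 4-nitrophenyl to phenyl gives the first step with a readable direction, an at least 2.9-fold lower number from compound 1 to compound 4 (0.46 log units; beyond the scatter), and that step lies beyond the scatter. Taking nitro off this aromatic carbon, para to a large group, therefore moves the number downward, at least for the benzyl amide pair shown. As far as these compounds go, whether an amine or a carboxylic acid at this same carbon would move the number further remains open. The full size of the step also remains open because the value of compound 1 is only a limit: the limit of > 100000 nM in this assay, at which 2 of the 4 values shown sit.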